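Ethylamino for hydroxy on a side chain

A few compounds are considered here, and "the series" means these few. Any claim that something is new, unique, unknown or untested is made for them only; others in the source may bear on it.

Measured so far in a functional assay on HeLa cells (Homo sapiens) for antiproliferative activity, read by MTT assay, with a stated time of 48 h; on this read-out lower numbers stand for stronger inhibition and higher numbers for weaker inhibition:

compound 1 `CNCC(=O)Nc1cc(OC)ccc1C(=O)c1ccc2c(c1)C=CC(C)(C)O2` gives 970 nM
compound 2 `CCNCC(=O)Nc1cc(OC)ccc1C(=O)c1ccc(OC)c2c1C=CC(C)(C)O2` gives 4270 nM
compound 3 `C=C(c1ccc(OC)cc1NC(=O)CO)c1ccc(OC)c2c1C=CC(C)(C)O2` gives 100 nM

Among these three, compound 3 holds the lowest number (100 nM), and its distance to each of the other two lies beyond the scatter. Compound 4 (`C=C(c1ccc(OC)cc1NC(=O)CNCC)c1ccc(OC)c2c1C=CC(C)(C)O2`) keeps the structure of compound 3 except for one change: ethylamino in place of hydroxy on a saturated chain carbon bound to a carbonyl carbon.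

Within the data shown here, no measured pair shows this change alone. Compound 2 also carries ethylamino on such a carbon and gives a much higher number (4270 nM). Compound 1 has an amino-bearing chain as well and also gives a higher number (970 nM). Both differ from compound 3 elsewhere in the structure too, so they hint at a direction but do not fix a size. The expected move is therefore towards weaker inhibition, of moderate size (a 3.0-fold higher number from compound 3 to compound 4 (0.48 log units; beyond the scatter)), though the uncertainty is wide. The estimate for compound 4 is 300 nM (expected range 70 nM to 1500 nM).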

Compound 4, half-maximal inhibitory concentration: 2590 nM
Estimate against measurement, compound 4: 8.6-fold (0.94 log units) below; measured number above the stated range.
By their numbers in this assay, from the lowest: compound 3; then compound 1; then compounds 4 and 2 (each within the scatter of the next).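

In this assay, the swap of hydroxy for ethylamino on a saturated chain carbon bound to a carbonyl carbon can now be read on its own, and a 26-fold higher number from compound 3 to compound 4 (1.41 log units; beyond the scatter) gives it a size. Compounds 1 and 2, which differ from compound 3 elsewhere as well, could only hint at that size. The position is therefore sensitive to this change, even though the two groups carry the same counts of hydrogen-bond donors and acceptors and differ in heavy atoms and their elements, with oxygen leaving and carbon and nitrogen entering. Nothing in the data given accounts for the size of this step.

A single pair cannot separate the part played by the nitrogen from the part played by the ethyl group, so a plain amino group, a methoxy group or a longer propylamino chain on the same carbon would be needed to tell them apart. Going by these compounds, it also remains open whether the swap would have a similar effect on the different cores of compounds 1 and 2.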